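A triazole exchange starting from compound 1

A few compounds are considered here, and "the series" means these few. Any claim that something is new, unique, unknown or untested is made for them only; others in the source may bear on it.

In an ADME assay on microsomes from liver (Rattus norvegicus) for metabolic stability (on this read-out lower numbers stand for a shorter-lived compound and higher numbers for a longer-lived compound), compound 1 (`CCn1ncc2c(F)cc(-c3ccc(C(CC)(CC)c4nnc(C)[nH]4)c(=O)[nH]3)cc21`) gives > 3 h; this is a limit of the assay and not a number. Compound 1 therefore stands at the limit of > 3 h in this assay, at which 1 of the 2 values shown sits. Among the compounds with values here, compound 2 (`CC(C)C(Cc1nnn[nH]1)c1ccc(-c2ccc3cccc(F)c3c2)[nH]c1=O`), the only other measured compound, gives 2.08 h, and no step in one place connects it to compound 1.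

Compound 3 (`CCn1ncc2c(F)cc(-c3ccc(C(CC)(CC)c4ncn(C)n4)c(=O)[nH]3)cc21`) has the same atoms as compound 1, joined differently. The 5-methyl-4H-1,2,4-triazol-3-yl gives way to 1-methyl-1H-1,2,4-triazol-3-yl on a saturated chain carbon bound to an aromatic carbon and two saturated chain carbons: 1-methyl-1H-1,2,4-triazol-3-yl in place of 5-methyl-4H-1,2,4-triazol-3-yl on a saturated chain carbon bound to an aromatic carbon and two saturated chain carbons.

Within the data shown here, no measured step in this assay covers this exchange, so the expectation is loose: no change beyond the scatter, with a slight lean towards a shorter half-life. The expectation starts from compound 1 with its > 3 h, which is only a limit. The estimated change is an at least 1.2-fold lower number from compound 1 to compound 3 (0.07 log units; that floor lies within the scatter). For compound 3 the estimate is 2.5 h, with an expected range of 1.2 h to 4 h.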

Compound 3, half-life: > 3 h
Compound 3: a limit, no number; the forecaster's own chance of this, stated with the estimate: 40%; middle value at least 1.2-fold (0.07 log units) from the limit.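

Compound 1 and compound 3 both stand at a limit and not at a number, so no step between them can be read in this assay: the limit of > 3 h in this assay, at which 2 of the 3 values shown sit.

The compounds shown leave open whether 1-methyl-1H-1,2,4-triazol-3-yl in place of 5-methyl-4H-1,2,4-triazol-3-yl changes the half-life at all, and in which direction.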